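The source may hold more compounds than are shown below. What is called first, only, known or untested is meant among the compounds shown, and "the series" means these compounds.

Measured in a functional assay on HT-29 cells (Homo sapiens) for antiproliferative activity, read by sulforhodamine B assay, with a stated time of 72 h; a lower number here means a stronger inhibitor, a higher number a weaker inhibitor:
- Compound 1 `COc1cccc(NC(=S)N/N=C/c2ccc3ccccc3n2)c1`: 82400 nM
- Compound 2 `S=C(N/N=C/c1ccc2ccccc2n1)Nc1ccccc1Br`: > 100000 nM (a limit of the assay, not a number)

Compound 2 has no measured number on this read-out, only the limit > 100000 nM. That places it at the edge of what this assay can report, and the record shows (the limit of > 100000 nM in this assay, at which 1 of the 2 values shown sits). The next compound, compound 3 `Fc1ccc(NC(=S)N/N=C/c2ccc3ccccc3n2)cc1`, keeps the shared core and carries 4-fluorophenyl in place of 2-bromophenyl on an amide-type nitrogen.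

Within the data shown here, one measured step bears on this change, since it alters the same place: an at least 1.2-fold higher number from compound 1 to compound 2 (0.08 log units; that floor lies within the scatter). That step is only a floor and lies within the scatter, so it gives no measured size for a substitution here. The one actual number among these compounds is that of compound 1, at 82400 nM, and it sets the expectation of weak activity. A modest move to a lower number is expected, with a real chance that compound 3 also reaches the limit. The expected change is an at least 1.6-fold lower number from compound 2 to compound 3 (0.22 log units; that floor lies within the scatter). For compound 3 the estimated value is 60000 nM, with an expected range from 15000 nM to 100000 nM.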

Compound 3, half-maximal inhibitory concentration: 28500 nM
Compound 3: the middle estimate sits 2.1-fold (0.32 log units) above what was measured; the range from low to high includes it.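

In this assay, the position on the amide-type nitrogen now shows a measured response: with 4-fluorophenyl in place of 3-methoxyphenyl, the change is a 2.9-fold lower number from compound 1 to compound 3 (0.46 log units; beyond the scatter), a modest step that the earlier pair could not provide. Putting 4-fluorophenyl in place of 2-bromophenyl gives an at least 3.5-fold lower number from compound 2 to compound 3 (0.54 log units; beyond the scatter), so this change also clears the scatter, although the printed figure is a floor and not a full size. Compound 2 has a limit of the assay and not a number, and the true size of this step stays unknown because of that limit: the limit of > 100000 nM in this assay, at which 1 of the 3 values shown sits.

The compounds shown do not separate the identity of the halogen from its place on the phenyl ring, since 2-bromophenyl and 4-fluorophenyl differ in both. They also leave open whether an amine or a carboxylic acid on that phenyl ring, or a longer alkyl chain in place of the ring, would move the number further from that of compound 3.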